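The compounds below may be only part of what the source reports. "The series", "measured", "known", "first", "only" and "open" are said of these compounds alone.

In an ADME assay on microsomes from liver (Mus musculus) for metabolic stability, tested at 5 uM (on this read-out higher numbers stand for a longer-lived compound and lower numbers for a shorter-lived compound), compound 1 `CCCCCCCCNc1ccc(C(=O)O)cc1S(N)(=O)=O` gives 0.3 h, compound 2 `CCCCCCNc1ccc(C(=O)O)cc1S(=O)(=O)N(C)C` gives 0.283 h, and compound 3 `CCCCCCCCNc1ccc(C(=O)O)cc1S(=O)(=O)N(C)C` gives 0.217 h. Compound 3 therefore stands within the scatter of both of the others, and these numbers show no real separation among the three compounds.

The next compound to be tested is compound 4 `CN(C)S(=O)(=O)c1cc(C(=O)O)ccc1NCCC(C)(C)C`. Its change from compound 3 lies in the chain on the nitrogen: tert-butyl in place of hexyl on a saturated chain carbon, two bonds along the chain from a nitrogen on an aromatic ring. Put another way, tert-butyl takes the place of hexyl, which, cut one bond further out, reads octyl to 3,3-dimethylbutyl.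

Two measured steps offer guidance. The closer one also alters the chain, and it gives a 1.3-fold lower number from compound 2 to compound 3 (0.12 log units; within the scatter). The other alters the sulfonyl group instead, with dimethylamino in place of amino on a sulfonyl sulfur, and it gives a 1.4-fold lower number from compound 1 to compound 3 (0.14 log units; within the scatter). For the measured compounds named here, neither step goes beyond the scatter, but no compound measured so far carries a tert-butyl-ended chain, so this guidance is limited.

A step beyond the scatter is therefore not expected in this assay, and no direction can be favoured. The estimate amounts to a 1.4-fold higher number from compound 3 to compound 4 (0.14 log units; within the scatter), which is an expected difference of no real size. The estimated half-life of compound 4 is 0.3 h, with an expected range from 0.15 h to 0.6 h.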

Compound 4, half-life: > 1 h
Compound 4: no number, only a limit; the forecaster's own chance of this, stated with the estimate: 3%; middle value at least 3.3-fold (0.52 log units) away from the limit.
By their numbers in this assay, from the lowest: compounds 3, 2 and 1 (each within the scatter of the next). At a limit, above all of these: compound 4.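

In this assay, for the compounds shown here, this place on the chain on the nitrogen is the first to give a step beyond the scatter, with an at least 4.6-fold higher number from compound 3 to compound 4 (0.66 log units; beyond the scatter) and an at least 3.5-fold higher number from compound 2 to compound 4 (0.54 log units; beyond the scatter). The earlier changes, in the straight chain and on the sulfonyl sulfur, had all stayed within the scatter, whereas the second step here swaps butyl for tert-butyl at the same place, so a chain ending in tert-butyl behaves unlike the straight chains of compounds 2 and 3. The reading for compound 4 is a limit and not a number, so both steps give only a smallest size and the full size remains unknown: the limit of > 1 h in this assay, at which 1 of the 4 values shown sits.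

The compounds shown leave open whether this belongs to tert-butyl alone or would also appear with another chain end, such as isopropyl or cyclohexyl. They also leave open whether the 3,3-dimethylbutyl chain would act the same way with the amino group of compound 1 on the sulfonyl sulfur in place of dimethylamino.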